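Moving One Fluorine on a Rapidly Cleared Compound

The source may hold more compounds than are shown below. What is called first, only, known or untested is meant among the compounds shown, and "the series" means these compounds.

So far three compounds have been measured in an ADME assay on liver for metabolic stability, with Liver microsome (Homo sapiens) as the target, read by LC-MS, using microsomes, with a stated time of 5 h; a higher number here means faster removal of the compound, a lower number slower removal. Among them, compound 1 `OC(c1ncccc1F)C1(c2ccc(Cl)c(Cl)c2)CCC1` gives the highest number at 833 mL/min/kg and is removed fastest. Compound 2 `O[C@H](c1ccccn1)[C@]1(c2cccc(OC(F)(F)F)c2)C[C@@H](O)C1` gives a clearly lower 117 mL/min/kg and compound 3 `O[C@H](c1ccccn1)[C@]1(c2cc(C(F)(F)F)ccn2)C[C@H](O)C1` gives a lower number still at 33.3 mL/min/kg in the same test.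

The next compound to be tested is compound 4 `OC(c1cc(F)ccn1)C1(c2ccc(Cl)c(Cl)c2)CCC1`. It keeps the core of compound 1 and carries one change: 4-fluoropyridin-2-yl in place of 3-fluoropyridin-2-yl on a saturated chain carbon bound to an oxygen on a saturated carbon and a saturated ring carbon.

The two compounds have the same atoms, joined differently. Going by the values given here, no two measured compounds differ in one place only, so no measured step shows how large such a change might be. The expectation therefore rests on the structures alone: in this assay no step beyond the scatter is expected, and compound 4 should stay close to compound 1 at 833 mL/min/kg in the measurement. The estimated change is a 1.2-fold lower number from compound 1 to compound 4 (0.08 log units; within the scatter) and it remains within the scatter. For compound 4 the estimated clearance is 700 mL/min/kg with an expected range from 300 mL/min/kg to 1500 mL/min/kg at the upper end.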

Compound 4, clearance: 533 mL/min/kg
The estimate for compound 4 lay 1.3-fold (0.12 log units) above the measured number; measured number inside the range.
By their numbers in this assay, from the lowest: compound 3; then compound 2; then compounds 4 and 1 (each within the scatter of the next).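

Going by these compounds alone, replacing 3-fluoropyridin-2-yl with 4-fluoropyridin-2-yl on the saturated chain carbon gives a 1.6-fold lower number from compound 1 to compound 4 (0.19 log units; within the scatter) in this assay and provides the first direct one-place comparison at this position. Since this step stays within the usual scatter of repeated measurements, the test does not separate these two fluorine placements, and compound 4 cannot be ranked against compound 1. Nothing available explains this result or shows how either compound is removed.

Moving the fluorine within the ring is only one kind of change at this position, so it remains open whether replacing the whole fluoropyridine with a different group, such as an amine or a carboxylic acid, would produce a step beyond the scatter on the core of compound 1. On these data alone, it is also open how a pyridin-2-yl group without fluorine, or one carrying a nitrile in place of the fluorine, would read on that same core.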